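Ester chain length and cytotoxicity read-out in the shared core

The compounds below may be only part of what the source reports. "The series", "measured", "known", "first", "only" and "open" are said of these compounds alone.

Measured so far in a functional assay on A549 cells (Homo sapiens) for cytotoxicity, read by MTT assay, with a stated time of 24 h, tested at 60 uM; a lower number here means a stronger effect, a higher number a weaker effect of the compound at the concentration tested:
compound 1 `CCCCCCCCCCOC(=O)CCC(=O)N1CCN(CCCOc2cc3c(Nc4ccc(F)c(Cl)c4)ncnc3cc2OC)CC1` gives 3.9%
compound 2 `CCCCCCCCCCCCCCOC(=O)CCC(=O)N1CCN(CCCOc2cc3c(Nc4ccc(F)c(Cl)c4)ncnc3cc2OC)CC1` gives 84.9%

Compound 2 stands highest of the two numbers; its nearest neighbour is compound 1, and the step between them is a number 81 percentage points higher from compound 1 to compound 2 (beyond the scatter). Compound 3 `CCCCCCCCCCCCCCCCCCOC(=O)CCC(=O)N1CCN(CCCOc2cc3c(Nc4ccc(F)c(Cl)c4)ncnc3cc2OC)CC1` differs from compound 2 by butyl in place of hydrogen on a saturated chain carbon, ten or more bonds along the chain from an oxygen next to a carbonyl group. Within the data shown here, the one measured step that bears on this change is a number 81 percentage points higher from compound 1 to compound 2 (beyond the scatter), the same change made one stage earlier along the chain. The read-out of compound 2 leaves little room above it, so for compound 3 a small upward step, or none beyond the scatter, is expected: a number 6.1 percentage points higher from compound 2 to compound 3 (within the scatter). Compound 3 is estimated at 91%, with a range from 74% to 100%.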

Compound 3, a percentage reported as activity, at one concentration (the size of the read-out at that concentration, not a potency): 87.2%
Estimate against measurement, compound 3: 3.8 percentage points above; the measured number falls inside the stated range.
By their numbers in this assay, from the lowest: compound 1; then compounds 2 and 3 (each within the scatter of the next).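

In this assay the same butyl change, made one stage further out, gives a number 2.3 percentage points higher from compound 2 to compound 3 (within the scatter), so the large step seen earlier does not repeat at this position. The full octyl change gives a number 83.3 percentage points higher from compound 1 to compound 3 (beyond the scatter), which places the whole of the large difference in the first butyl change, with compound 2 and compound 3 within the scatter of each other. No measurement shown gives a reason for this behaviour.

Open, from the compounds shown here alone, is where, among chains between those of compound 1 and compound 2, the read-out turns. Also open, going by these compounds, is whether a carboxylic acid or an amine on the chain would change it.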